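Trimethylcyclohexenyl dienone series: aryl methoxylation and HeLa cytotoxicity

The source may report more compounds than this note shows. Statements on the series, on what has been measured and on what is new or still open speak of the compounds shown alone.

Measured compounds:
Compound 1, `CC1=C(/C=C/C(=O)/C=C/c2ccccc2)C(C)(C)CCC1`, in a functional assay on HeLa cells (Homo sapiens) for cytotoxicity, read by sulforhodamine B assay, with a stated time of 48 h; a higher number here means a weaker inhibitor, a lower number a stronger inhibitor: 70200 nM
Compound 2, `COc1ccccc1/C=C/C(=O)/C=C/C1=C(C)CCCC1(C)C`, in this assay: 88200 nM
Compound 3, `COc1ccc(/C=C/C(=O)/C=C/C2=C(C)CCCC2(C)C)cc1OC`, in this assay: 85000 nM

All three share one core and differ only in the aryl ring. From compound 1 to compound 2 the change is methoxy in place of hydrogen on an aromatic carbon, and the step is a 1.3-fold higher number from compound 1 to compound 2 (0.10 log units; within the scatter). How compound 3 differs from compound 1 is not broken down here; the values of compound 3 and compound 2 lie within the scatter of each other, so nothing is said about their order.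

Compound 4, `COc1cc(/C=C/C(=O)/C=C/C2=C(C)CCCC2(C)C)cc(OC)c1OC`, is not yet measured. It differs from compound 3 by methoxy in place of hydrogen on an aromatic carbon. This is the same kind of change as that from compound 1 to compound 2, not the same: there the place was ortho to a large group, here it is ortho to a methoxy group, meta to a large group and meta to a methoxy group.

The expected step in this assay is a 1.1-fold higher number from compound 3 to compound 4 (0.02 log units; within the scatter), resting on the earlier step of a 1.3-fold higher number from compound 1 to compound 2 (0.10 log units; within the scatter) being within the scatter. For compound 4 the estimate is 90000 nM, with a likely range from 45000 nM to 180000 nM.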

Compound 4, half-maximal inhibitory concentration: 73200 nM
The estimate for compound 4 lay 1.2-fold (0.09 log units) above the measured number; the measured number falls inside the stated range.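

Methoxy in place of hydrogen on an aromatic carbon, here ortho to a methoxy group, gives a 1.2-fold lower number from compound 3 to compound 4 (0.06 log units; within the scatter) in this assay. Set beside the earlier step, the two readings cannot be told apart: the same change on two cores in this assay, a 1.3-fold higher number (0.10 log units; within the scatter) from compound 1 to compound 2 and a 1.2-fold lower number (0.06 log units; within the scatter) from compound 3 to compound 4, 1.5-fold (0.16 log units) apart, within the scatter of two such steps. In these two cases the change therefore carries from one core to the other without a detectable difference, but it does not show that the two steps are the same, since both are small and a difference smaller than the scatter would go unseen; nor does it say anything about other cell lines or other assays.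

The aryl rings shown carry only hydrogen or methoxy, so it remains open whether an amine, a carboxylic acid or fluorine on that ring would give a step beyond the scatter. Also open, going by these compounds, is whether a longer chain in place of the dienone link would do so.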